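From Propyl to Methyl at the Chain Carbon

The source may hold more compounds than are shown below. What is called first, only, known or untested is meant among the compounds shown, and "the series" means these compounds.

The compounds with a number so far:
- compound 1, `CCCOC(=O)/C=C/c1ccc(C(C)C)cc1`; in a functional assay on the whole organism for inhibition, with Brassica rapa subsp. chinensis as the target, with a stated time of 3 days, tested at 100 ppm (a lower number here means less inhibition of growth, a higher number more inhibition of growth at the concentration tested), compound 1 gives 5%
- compound 2, `CC(C)=CCCC(C)CCOC(=O)/C=C/c1ccc(C(C)C)cc1`; in this assay compound 2 gives 0%
- compound 3, `CC(C)c1ccc(/C=C/C(=O)OCCOc2ccccc2)cc1`; in this assay compound 3 gives 0%

Compound 1 holds the highest of the three numbers, but only by a small margin: the step of a number 5 percentage points lower from compound 1 to compound 2 (within the scatter) and the step of a number 5 percentage points lower from compound 1 to compound 3 (within the scatter) both fall within the scatter, as does no change at the digits printed from compound 2 to compound 3 (within the scatter). Among the compounds with values here, on these numbers no compound can be told apart from the others, and all three sit close to no inhibition at all.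

Compound 4, `COC(=O)/C=C/c1ccc(C(C)C)cc1`, differs from compound 1 by hydrogen in place of ethyl on a saturated chain carbon bound to an oxygen next to a carbonyl group. The measured steps that bear on this change are the two from compound 1, which alter the same region of the chain, the saturated carbon two bonds along from the oxygen next to the carbonyl group; both were within the scatter. A change at the carbon bound to that oxygen, shortening the chain to methyl, is therefore expected to give no step beyond the scatter in this assay, which is to say no change at the digits printed from compound 1 to compound 4 (within the scatter). Compound 4 is estimated at 5%, with a range from 0% to 15%.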

Compound 4, percent growth inhibition at one concentration: 21%
For compound 4 the middle estimate is 16 percentage points below the measured one; the whole stated range lies below it.
By their numbers in this assay, from the lowest: compounds 2, 3 and 1 (each within the scatter of the next); then compound 4.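

Among the steps shown so far, this is the only one that lies beyond the scatter in this assay: hydrogen in place of ethyl on a saturated chain carbon bound to an oxygen next to a carbonyl group gives a number 16 percentage points higher from compound 1 to compound 4 (beyond the scatter). The earlier changes to the chain of compound 1 left no readable difference, so the chain is not silent to every change, and here propyl to methyl, or propoxy to methoxy, registers as a modest step. Nothing available bears on the cause of this step.

The compounds shown leave open whether ethoxy would stand with compound 1 or with compound 4, and whether a carboxylic acid or an amide at this end of the molecule would carry the number further. They also leave open whether the step seen at this single concentration would hold at other concentrations.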